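Removing a Methyl from a Pyrimidine and Pyridine Core

This account rests on a few compounds, and the source may have more. Where it says the series, first, only, none or still open, it means among the compounds named here.

Measured compounds:
compound 1 `Cc1cc(C#Cc2ccc(CCC(=O)O)cc2)nc(Cl)n1` gives 2750 nM;
compound 2 `Cc1c(C#Cc2ccc(CCC(=O)O)cc2)cc(Cl)nc1Cl` gives 43.7 nM;
compound 3 `O=C(O)CCc1ccc(C#Cc2ccnc(Cl)n2)cc1` gives 9120 nM.

All three compounds were tested in an in vitro functional assay on 1321-N1 cells for agonist activity at Free fatty acid receptor 1 (Homo sapiens), read by fluorescence, spectrophotometry and calcium flux; a higher number here means that more compound is needed for the effect, a lower number that less compound is needed. Compound 2 stands lowest of the three numbers, and its steps to both others lie beyond the scatter.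

Compound 1 and compound 3 differ in one place: hydrogen in place of methyl on an aromatic carbon. This change produced a 3.3-fold higher number from compound 1 to compound 3 (0.52 log units; beyond the scatter) in this assay, so taking the methyl away made more compound necessary for the effect.

Compound 4 `O=C(O)CCc1ccc(C#Cc2cc(Cl)nc(Cl)c2)cc1` has not yet been measured. It differs from compound 2 in one place: hydrogen in place of methyl on an aromatic carbon. This is the same kind of change as that from compound 1 to compound 3, but the surroundings are not identical. In compound 1 the methyl sits on a ring with 2 nitrogen, next to the ring nitrogen, meta to a chloro group, meta to a large group and opposite the ring nitrogen; in compound 2 it sits on a ring with 1 nitrogen, ortho to a chloro group, ortho to a large group, two atoms from the ring nitrogen and para to a chloro group. The difference between the two cores of compound 1 and compound 2 is not broken down here.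

Compound 4 is expected to show a 3.4-fold higher number from compound 2 to compound 4 (0.54 log units; beyond the scatter) in this assay, a step of similar size to the one seen because the methyl removal from compound 1 to compound 3 gave a 3.3-fold higher number from compound 1 to compound 3 (0.52 log units; beyond the scatter). The different surroundings of the methyl make the size uncertain. Compound 4 is therefore estimated at 150 nM, expected to fall between 50 nM and 500 nM.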

Compound 4, half-maximal effective concentration: 40.7 nM
Compound 4: middle estimate off by 3.7-fold (0.57 log units), on the high side, and the stated range ends above it.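

In this assay the same swap of methyl for hydrogen on a pyridine-type ring with 1 nitrogen gives a 1.1-fold lower number from compound 2 to compound 4 (0.03 log units; within the scatter) and so leaves the two compounds indistinguishable. The step seen on the core of compound 1 therefore did not carry over to this second core, and the two results differ by more than the scatter allows: the same change on two cores in this assay, a 3.3-fold higher number (0.52 log units; beyond the scatter) from compound 1 to compound 3 and a 1.1-fold lower number (0.03 log units; within the scatter) from compound 2 to compound 4, 3.6-fold (0.55 log units) apart, beyond the scatter of two such steps

This shows that, in this series, the size of the step for this methyl removal depends on the core that carries the methyl, so a step measured on one core is not a safe forecast for another. It does not show what in the cores is responsible, since they differ in more than one feature and the methyl has different surroundings on each, and two pairs of compounds cannot establish a rule for other cores.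

The compounds shown leave open how a larger group at this place, such as an ethyl or a methoxy group, would compare with hydrogen and methyl on each core. They also leave open whether an amine in place of one of the chloro groups would alter how the core responds to the methyl removal.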